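The source may report more compounds than this note shows. Statements on the series, on what has been measured and on what is new or still open speak of the compounds shown alone.

Of the compounds shown here, two have been measured in a functional assay on H4 cells for agonist activity at growth hormone secretagogue receptor type 1 (Homo sapiens), read by FLIPR; on this read-out lower numbers stand for an effect already at smaller amounts and higher numbers for an effect only at larger amounts of compound. Compound 1 `CC(C)(N)C(=O)N[C@H](COCc1ccccc1)c1nnnn1CCCCCNS(C)(=O)=O` gives 75 nM in this assay. Compound 2 `CC(C)(N)C(=O)N[C@H](COCc1ccccc1)c1nnn(Cc2ccccc2)n1` gives 1120 nM in this assay, the highest of the two numbers; its nearest neighbour is compound 1, and the gap between these two numbers lies beyond the usual scatter. The two compounds differ in more than one place, so the gap is not read as a single step and no cause is assigned to it.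

Compound 3 `CC(C)(N)C(=O)N[C@H](COCc1ccccc1)c1nnn(Cc2ccc(NS(C)(=O)=O)cc2)n1` has not yet been measured in this assay. It differs from compound 2 in one place: methanesulfonamido in place of hydrogen on an aromatic carbon. Within the data shown here, no pair among the measured compounds shows this exact change, so the size of the step cannot be taken from a measured one. Compound 1, which carries a methanesulfonamido group on a chain rather than on a ring, gives 75 nM, but that is not a single-step comparison and serves only as a loose orientation. In this assay the expected step is a 2.2-fold lower number from compound 2 to compound 3 (0.35 log units; beyond the scatter), a move toward lower numbers of moderate size, with wide uncertainty. Compound 3 is estimated at 500 nM in this assay, with a range from 150 nM to 2000 nM.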

Compound 3, half-maximal effective concentration: 986 nM
Estimate against measurement, compound 3: 2.0-fold (0.29 log units) below; the range from low to high includes it.
By their numbers in this assay, from the lowest: compound 1; then compounds 3 and 2 (each within the scatter of the next).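

In this assay, among these compounds, the first step that can be read at a single place is a 1.1-fold lower number from compound 2 to compound 3 (0.06 log units; within the scatter), so the numbers of the two compounds cannot be told apart. At this position, on an aromatic carbon para to a large group, methanesulfonamido can thus take the place of hydrogen with no effect that can be separated from the scatter of this read-out, even though it brings in a sulfur, a nitrogen and two oxygen atoms. Nothing at hand explains why this change gives so small a step, and no measurement bearing on this result is available.

As far as these compounds go, whether another group on the same ring carbon, such as an amine, a carboxylic acid or a methoxy group, would give a step beyond the scatter stays open, as does the effect of methanesulfonamido on a different carbon of the ring. Also open, from the compounds shown here alone, is what part of the gap to compound 1 belongs to a longer chain carrying the methanesulfonamido group, since compound 1 differs from the others in more than one place.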